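A few compounds are considered here, and "the series" means these few. Any claim that something is new, unique, unknown or untested is made for them only; others in the source may bear on it.

Two esters built on a shared core have been tested in a functional assay on MCF7 cells (Homo sapiens) for antiproliferative activity, read by sulforhodamine B assay, with a stated time of 48 h, tested at 50 uM; on this read-out higher numbers stand for more inhibition at the one concentration tested (going by the name of the read-out) and lower numbers for less inhibition. Compound 1 `Cc1cc2c(C(C)C)ccc(C)c2cc1OC(=O)c1cccc(C(F)(F)F)c1` gives 41.5% in this assay, while compound 2 `CC1=CC[C@H](C(C)C)c2cc(C)c(OC(=O)c3cccc(C)c3)cc21` gives 54.9%, the higher of the two numbers, and the gap between them lies beyond the usual scatter. Compound 3 `CC1=CC[C@H](C(C)C)c2cc(C)c(OC(=O)c3ccccc3)cc21` has not yet been measured. It differs from compound 2 in one place: hydrogen in place of methyl on an aromatic carbon. Going by the values given here, no measured pair shows this kind of step, so its size is not known from the data; a small step, within the scatter and if anything downward, is expected. Compound 3 is therefore estimated to give 48%, somewhere between 30% and 65%. The expected step is a number 6.9 percentage points lower from compound 2 to compound 3 (within the scatter).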

Compound 3, a percentage reported as inhibition, at one concentration (the size of the read-out at that concentration, not a potency): 60.7%
Compound 3: the middle estimate sits 12.7 percentage points below what was measured, and the stated range covers the measured number.
By their numbers in this assay, from the lowest: compound 1; then compounds 2 and 3 (each within the scatter of the next).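

In this assay, trading 3-methylphenyl for phenyl gives a number 5.8 percentage points higher from compound 2 to compound 3 (within the scatter). At this one concentration, then, the inhibition does not depend on this methyl on the aromatic ring, and the plain phenyl ester serves as well as the methylated one. No measurement shown gives a reason for this result. Still open, from the compounds shown here alone, is whether a different group at this place, such as a methoxy group, a chlorine atom or an amine, would leave the number unchanged. Going by these compounds, whether this single step holds on any other core is also open.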